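Adding a Chloro Group to the Phenyl of Compound 3

The source may report more compounds than this note shows. Statements on the series, on what has been measured and on what is new or still open speak of the compounds shown alone.

compound 1, `CCOC(=O)c1c(N)cc(O)n1-n1c(C)nc2ccccc2c1=O`: 11500 nM
compound 2, `Cc1nc2ccccc2c(=O)n1Nc1csc(N)n1`: 400 nM
compound 3, `Cc1nc2ccccc2c(=O)n1NC(=O)/C(Cl)=C/c1ccccc1`: 50 nM

Of the compounds shown here, three that share one core have been measured in a functional assay on SF-268 cells (Homo sapiens) for inhibition, read by sulforhodamine B assay, with a stated time of 48 h; a higher number here means a weaker inhibitor of growth, a lower number a stronger inhibitor of growth. Compound 3 gives the lowest of the three numbers. The nearest to it is compound 2, whose number is higher by a margin beyond the scatter of this assay, and the furthest is compound 1, whose number lies far higher still, also well beyond the scatter. Among the compounds with values here, compound 3 thus stands as the strongest inhibitor of growth among the three measured so far.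

The next compound, compound 4, `Cc1nc2ccccc2c(=O)n1NC(=O)/C(Cl)=C/c1ccc(Cl)cc1`, differs from compound 3 in one place: chloro in place of hydrogen on an aromatic carbon. Within the data shown here, no step of this kind has been measured within this set, so the expectation rests only on the value of compound 3 and on the smallness of the change. A single chloro group entering on the phenyl ring is expected to move the number little, most likely not beyond the scatter, with a slight lean toward a lower number. For compound 4 the estimate in this assay is 40 nM, with a range from 15 nM to 130 nM, which corresponds to an expected step of a 1.3-fold lower number from compound 3 to compound 4 (0.10 log units; within the scatter).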

Compound 4, concentration for 50% growth inhibition: 50800 nM
Estimate against measurement, compound 4: 1300-fold (3.10 log units) below, outside the stated range (above it).
By their numbers in this assay, from the lowest: compound 3; then compound 2; then compound 1; then compound 4.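

In this assay, within the data shown here, the change from phenyl to 4-chlorophenyl gives a 1000-fold higher number from compound 3 to compound 4 (3.01 log units; beyond the scatter) as a large step, and this is the first step in the set between two compounds that differ in one place. It shows that this position, on an aromatic carbon para to a large group, is far from indifferent: a single chloro group in place of hydrogen is enough to turn one of the lowest numbers in the set into a very high one, so the phenyl of compound 3 cannot be regarded as open to any small addition. No measurement at hand bears on what lies behind a step of this size.

On these data alone, with this one replacement alone, it stays open whether the step belongs to chloro in particular or to any group on this carbon, and a fluoro group, a methyl group, a methoxy group or an amine in the same place would separate those two readings. As far as these compounds go, it also stays open whether chloro on another carbon of the phenyl ring would give a step of similar size or a much smaller one.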